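Shortening the Ether Chain: From Compound 1 to Compound 3

The source may report more compounds than this note shows. Statements on the series, on what has been measured and on what is new or still open speak of the compounds shown alone.

Compound 1 `CCOc1ccc(S(=O)(=O)N2CCN(c3cccc(C)c3)CC2)cc1S(=O)(=O)N1CCN(c2cccc(C)c2)CC1` was examined in an ADME assay on L929 cells (Mus musculus) for cytotoxicity, read by CCK-8 assay, with a stated time of 48 h, tested at 10 uM (on this read-out lower numbers stand for a stronger effect and higher numbers for a weaker effect at the one concentration tested), where compound 1 gives 56.6%. This is the lowest of the two numbers recorded so far. Its nearest neighbour, compound 2 `COc1ccc(S(=O)(=O)N2CCN(C)CC2)cc1S(=O)(=O)N1CCN(C)CC1`, gives 77.8% in this assay, a gap beyond the usual scatter. Among the measured compounds shown here, compound 2 differs from compound 1 in more than one place, so the two values show only that compound 1 sits lower.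

Compound 3 `COc1ccc(S(=O)(=O)N2CCN(c3cccc(C)c3)CC2)cc1S(=O)(=O)N1CCN(c2cccc(C)c2)CC1` has not yet been measured. It is related to compound 1 by a single change: hydrogen in place of methyl on a saturated chain carbon bound to an oxygen on an aromatic ring. For the measured compounds named here, no step between two measured compounds isolates this change, so any expectation rests on the modest nature of the difference, a methyl leaving and a hydrogen entering on a saturated chain carbon bound to an oxygen on an aromatic ring.

With such a small change, the step of a number 3.4 percentage points higher from compound 1 to compound 3 (within the scatter) is expected to show no size beyond the scatter in either direction. In this assay compound 3 is therefore estimated at 60%, with a range from 45% to 76%.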

Compound 3, a percentage reported as activity, at one concentration (the size of the read-out at that concentration, not a potency): 85.2%
The estimate for compound 3 lay 25.2 percentage points below the measured number, and the stated range ends below it.
By their numbers in this assay, from the lowest: compound 1; then compounds 2 and 3 (each within the scatter of the next).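

The exchange of ethoxy to methoxy, hydrogen in place of methyl on a saturated chain carbon bound to an oxygen on an aromatic ring, in this assay gives a number 28.6 percentage points higher from compound 1 to compound 3 (beyond the scatter) and shows that this position is not silent on this read-out, even though only one carbon leaves. With everything else in the structure held the same, the lower number of compound 1 goes with its ethoxy group in this pair, something the earlier comparison could not show, as its two compounds differ in more than one place. The data shown offer no measurement that accounts for a step of this size from so small a change.

The compounds shown leave open how the number responds to other groups at this place, such as a longer chain like propoxy or a hydroxyl group in place of the ether. As far as these compounds go, it also remains open whether an ethoxy group would bring a comparable step on the core of compound 2, which carries methoxy.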